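Replacing benzyl with dimethoxyphenyl on the warhead-bearing core

The source may report more compounds than this note shows. Statements on the series, on what has been measured and on what is new or still open speak of the compounds shown alone.

Compound 1 `C=C(Br)C(=O)Nc1cccc(-c2cn3nc(Cc4ccccc4)sc3n2)c1` gives 3000 nM in a functional assay on L1210 cells (Mus musculus) for inhibition, read by cell counting, with a stated time of 2 days (on this read-out lower numbers stand for stronger inhibition and higher numbers for weaker inhibition), the lowest of the three numbers measured. Compound 2 `Nc1cccc(-c2cn3nc(Cc4ccccc4)sc3n2)c1` gives 7400 nM, and the step of a 2.5-fold higher number from compound 1 to compound 2 (0.39 log units; beyond the scatter) marks the loss of the bromoacrylamide. Compound 3 `Nc1cccc(-c2cn3c(-c4ccc(Cl)cc4)csc3n2)c1` gives 22000 nM; it differs from compound 2 in more than one place, so its value is only taken as it stands. Compound 4 `C=C(Br)C(=O)Nc1cccc(-c2cn3nc(-c4ccc(OC)c(OC)c4)sc3n2)c1` keeps the bromoacrylamide of compound 1 and changes the core substituent: 3,4-dimethoxyphenyl in place of benzyl on an aromatic carbon. Among the measured compounds shown here, no measured step touches this position, so no direction is backed by the data; the change is expected to fall within the scatter, as no change at the digits printed from compound 1 to compound 4 (within the scatter). Compound 4 is therefore estimated at 3000 nM, between 1000 nM and 10000 nM.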

Compound 4, half-maximal inhibitory concentration: 42 nM
Compound 4: middle estimate off by 71-fold (1.85 log units), on the high side; measured number below the stated range.
By their numbers in this assay, from the lowest: compound 4; then compound 1; then compound 2; then compound 3.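

This position on the shared core strongly affects the read-out: in this assay, with 3,4-dimethoxyphenyl in place of benzyl, the data show a 71-fold lower number from compound 1 to compound 4 (1.85 log units; beyond the scatter). Among the compounds shown here, that step is much larger than the one for loss of the bromoacrylamide, a 2.5-fold higher number from compound 1 to compound 2 (0.39 log units; beyond the scatter), which was the only single-place step available before. Nothing measured here accounts for the size of the step.

Open, as far as these compounds go, is whether a plain phenyl or a phenyl with a single methoxy group would give a similar number. Also open, from the compounds shown here alone, is whether 3,4-dimethoxyphenyl has the same effect with the free amine of compound 2 in place of the bromoacrylamide.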